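Swapping a dichlorophenyl for a dimethoxyphenyl on the ketone

The source may hold more compounds than are shown below. What is called first, only, known or untested is meant among the compounds shown, and "the series" means these compounds.

The measured compounds and their values:
compound 1, `COc1cc(-c2cc(/C=C/C(=O)c3ccc(Cl)c(Cl)c3)[nH]n2)cc(OC)c1OC`, 8650 nM;
compound 2, `COc1ccc(-c2cc(/C=C/C(=O)c3ccc(N)cc3)[nH]n2)cc1OC`, 4420 nM;
compound 3, `COc1ccc(-c2cc(/C=C/C(=O)c3cc(OC)c(OC)c(OC)c3)[nH]n2)cc1OC`, 2020 nM.

All three were tested in a functional assay on MDA-MB-231 cells (Homo sapiens) for inhibition, read by sulforhodamine B assay, with a stated time of 48 h; a lower number here means a stronger inhibitor of growth, a higher number a weaker inhibitor of growth. Compound 1 has the highest of the three numbers, so it is the weakest growth inhibitor in the set. Compound 2 lies within the usual scatter of compound 1, so no order between these two can be read. Compound 3 sits beyond the scatter from compound 1 and is clearly the stronger inhibitor of the pair.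

The next compound, compound 4, `COc1ccc(C(=O)/C=C/c2cc(-c3cc(OC)c(OC)c(OC)c3)n[nH]2)cc1OC`, has not yet been measured. Its structure differs from compound 1 in one place: 3,4-dimethoxyphenyl in place of 3,4-dichlorophenyl on a carbonyl carbon. The 3,4-dimethoxyphenyl group that enters is also found in compound 3, though at a different place in that molecule.

Going by the values given here, no directly comparable step between measured compounds exists, so the expectation rests on the spread of the three values. Compound 4 is expected to give a lower number than compound 1, with the step from a 2.9-fold lower number from compound 1 to compound 4 (0.46 log units; beyond the scatter) estimated to lie beyond the scatter. For compound 4 the value in this assay is estimated at 3000 nM, within a range of 1200 nM to 8000 nM.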

Compound 4, concentration for 50% growth inhibition: 1480 nM
Compound 4: the middle estimate sits 2.0-fold (0.31 log units) above what was measured; low and high end bracket the measured number.
By their numbers in this assay, from the lowest: compounds 4 and 3 (each within the scatter of the next); then compounds 2 and 1 (each within the scatter of the next).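

Going by these compounds alone, compound 1 and compound 4 differ in one place only, so this pair gives the first clean reading of a single change in this assay: placing 3,4-dimethoxyphenyl in place of 3,4-dichlorophenyl on a carbonyl carbon gives a 5.8-fold lower number from compound 1 to compound 4 (0.77 log units; beyond the scatter). The earlier compounds shown here differed from one another in more than one place, so they could not tie a difference in growth inhibition to this position, whereas this step shows that the number responds to what is carried on this six-membered aromatic ring, even though the ring itself stays the same and the rest of the molecule is unchanged. The change swaps two chlorine atoms for two methoxy groups, but no measurement here explains why the number moves.

Within the data shown here, it remains open whether both methoxy groups are needed, since a phenyl ring carrying only one methoxy group would separate their contributions. From the compounds shown here alone, it is also open how an unsubstituted phenyl ring, a hydroxyl group or an amine would compare at this same place on the core of compound 4.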